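A few compounds are considered here, and "the series" means these few. Any claim that something is new, unique, unknown or untested is made for them only; others in the source may bear on it.

Compound 1 `Oc1nnc(Br)c2c(Br)nc(Br)n12`, compound 2 `O=C(CSc1nncc2cncn12)c1ccccc1` and compound 3 `CC(C)CCSc1nncc2cncn12` have been measured. In a functional assay for inhibition, with Homo sapiens as the target (a higher number here means a weaker inhibitor, a lower number a stronger inhibitor), compound 1 gives 27000 nM and compound 3 gives 9000 nM. Compound 2 shows only > 48000 nM, which is a limit of the assay and not a number (the limit of > 48000 nM in this assay, at which 1 of the 3 values shown sits). Of the two numbers, compound 1 has the highest, and compound 3 sits lower by a gap beyond the usual scatter. Compound 4 `CCCc1nc(Br)c2c(Br)nnc(O)n12` differs from compound 1 in one place: propyl in place of bromo on an aromatic carbon. Within the data shown here, no measured pair shows this exchange in this assay, so the expected step of a 1.1-fold higher number from compound 1 to compound 4 (0.05 log units; within the scatter) is small, within the scatter, with no clear direction. Compound 4 is therefore estimated at 30000 nM, within a range from 8000 nM to 100000 nM.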

Compound 4, half-maximal inhibitory concentration: 48000 nM
Beside the measured number, compound 4's estimate is 1.6-fold (0.20 log units) below it; measured number inside the range.
By their numbers in this assay, from the lowest: compound 3; then compounds 1 and 4 (each within the scatter of the next).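

In this assay, among these compounds, the first reading of a change on this aromatic carbon between two ring nitrogen atoms gives a 1.8-fold higher number from compound 1 to compound 4 (0.25 log units; within the scatter). Propyl in place of bromo therefore leaves the number within the scatter, so this exchange shows no readable effect at this position. Compound 4 also stands at the same figure as the limit of the assay, which leaves little room to read any weaker compound as a number: the limit of > 48000 nM in this assay, at which 1 of the 4 values shown sits. On these data alone, whether an amine or a longer chain here would give a lower number remains open. So does the role of the two remaining bromo groups.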